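Benzyl Replacement on a Quinolone-like Core, Imidazolyl Step

The compounds below may be only part of what the source reports. "The series", "measured", "known", "first", "only" and "open" are said of these compounds alone.

Measured compounds:
compound 1, `Cc1cc(-c2c(F)cc3c(=O)c(Cc4ccc(Cl)cc4)cn(C4CC4)c3c2F)cc(C)n1`, 20000 nM
compound 2, `COc1cccc(Cc2cn(C3CC3)c3c(F)c(-c4cc(C)nc(C)c4)c(F)cc3c2=O)c1`, 20000 nM

The account follows a series measured in a functional assay on P388 cells (Mus musculus) for cytotoxicity; a higher number here means a weaker inhibitor, a lower number a stronger inhibitor. Compound 1 is `Cc1cc(-c2c(F)cc3c(=O)c(Cc4ccc(Cl)cc4)cn(C4CC4)c3c2F)cc(C)n1` and in this assay compound 1 gives 20000 nM. Compound 2 is `COc1cccc(Cc2cn(C3CC3)c3c(F)c(-c4cc(C)nc(C)c4)c(F)cc3c2=O)c1`, and in this assay compound 2 gives 20000 nM. Among the measured compounds shown here, the only step recorded between measured compounds is no change at the digits printed from compound 1 to compound 2 (within the scatter), with 3-methoxyphenyl in place of 4-chlorophenyl on a saturated chain carbon bound to an aromatic carbon. Compound 2 thus stands level with compound 1 at the digits shown, within the scatter.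

Compound 3 is `Cc1cc(-c2c(F)cc3c(=O)c(Cc4ncc[nH]4)cn(C4CC4)c3c2F)cc(C)n1`, not yet measured in this assay. The change from compound 2 is 1H-imidazol-2-yl in place of 3-methoxyphenyl on a saturated chain carbon bound to an aromatic carbon. For the measured compounds named here, the single relevant step, no change at the digits printed from compound 1 to compound 2 (within the scatter), shows that exchanging one aromatic group on the saturated chain carbon left the read-out unchanged; no step involving a five-membered ring with hetero atoms or a hydrogen-bond donor at that place has been measured. On this basis no shift beyond the scatter is expected, no change at the digits printed from compound 2 to compound 3 (within the scatter). Compound 3 is therefore estimated at 20000 nM, in the range 8000 nM to 40000 nM.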

Compound 3, half-maximal inhibitory concentration: 1100 nM
Compound 3: middle estimate off by 18-fold (1.26 log units), on the high side, and the stated range ends above it.
By their numbers in this assay, from the lowest: compound 3; then compounds 1 and 2 (each within the scatter of the next).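

The position on the saturated chain carbon bound to an aromatic carbon is not indifferent to what it carries: in this assay, 1H-imidazol-2-yl in place of 3-methoxyphenyl gives an 18-fold lower number from compound 2 to compound 3 (1.26 log units; beyond the scatter), and 1H-imidazol-2-yl in place of 4-chlorophenyl gives an 18-fold lower number from compound 1 to compound 3 (1.26 log units; beyond the scatter). Among the compounds shown here, the earlier pair had exchanged only one six-membered aromatic ring of carbon only for another, with no change in the read-out, so the response appears only with a five-membered aromatic ring with 2 hetero atoms and 1 hydrogen-bond donor, and compound 3 is the strongest inhibitor of the three. Nothing shown here accounts for this step.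

The change alters ring size, ring atoms and donor count together, so the compounds shown do not tell which of these goes with the lower number. A 1-methyl-1H-imidazol-2-yl group, a pyridin-2-yl group or an aminomethyl group at the same place would bear on that question, and so would a longer chain between the imidazole and the shared core.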